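Naphthoquinone-piperazine aryl series: working notes before compound 4

This account rests on a few compounds, and the source may have more. Where it says the series, first, only, none or still open, it means among the compounds named here.

Measured so far, in a functional assay on DU-145 cells (Homo sapiens) for inhibition, read by MTT assay, with a stated time of 72 h; a lower number here means a stronger inhibitor, a higher number a weaker inhibitor:
- compound 1, `O=C1C=C(N2CCN(c3ccc(Cl)cc3)CC2)C(=O)c2ccccc21`, gives 29500 nM
- compound 2, `COc1ccc(N2CCN(C3=CC(=O)c4ccccc4C3=O)CC2)cc1`, gives 46100 nM
- compound 3, `COc1ccccc1N1CCN(C2=CC(=O)c3ccccc3C2=O)CC1`, gives 8000 nM

Compound 2 holds the highest of the three numbers. Its nearest neighbour is compound 1, a 1.6-fold higher number from compound 1 to compound 2 (0.19 log units; within the scatter), a step within the scatter. Compound 3 is the furthest away, a 5.8-fold lower number from compound 2 to compound 3 (0.76 log units; beyond the scatter), a step beyond the scatter, as is a 3.7-fold lower number from compound 1 to compound 3 (0.57 log units; beyond the scatter).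

The next compound, compound 4, `O=C1C=C(N2CCN(c3ccc(F)c(Cl)c3)CC2)C(=O)c2ccccc21`, differs from compound 2 as follows: 3-chloro-4-fluorophenyl in place of 4-methoxyphenyl on an amine nitrogen in a ring. Among the compounds with values here, the only measured step that bears directly on this change is the exchange of methoxy for chloro on the aromatic carbon, a 1.6-fold higher number from compound 1 to compound 2 (0.19 log units; within the scatter), which stayed within the scatter. Compound 4 carries a chloro and a fluoro on that ring and no methoxy, so it is expected to fall close to compound 1 rather than compound 2. Nothing measured speaks to the added fluorine.

Compound 4 is therefore expected to give an estimate of 28000 nM, within a range of 10000 nM to 80000 nM. That estimate implies a step of a 1.6-fold lower number from compound 2 to compound 4 (0.22 log units; within the scatter), expected to stay within or just at the edge of the scatter.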

Compound 4, half-maximal inhibitory concentration: 32200 nM
The estimate for compound 4 lay 1.2-fold (0.06 log units) below the measured number; the range from low to high includes it.
By their numbers in this assay, from the lowest: compound 3; then compounds 1, 4 and 2 (each within the scatter of the next).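

Exchanging 4-methoxyphenyl for 3-chloro-4-fluorophenyl on the amine nitrogen in the ring gives a 1.4-fold lower number from compound 2 to compound 4 (0.16 log units; within the scatter) and exchanging 4-chlorophenyl for the same group gives a 1.1-fold higher number from compound 1 to compound 4 (0.04 log units; within the scatter) so neither the added fluoro nor the loss of the single hydrogen-bond acceptor of the methoxyphenyl group separates compound 4 from compound 1 or compound 2. Against the 2-methoxyphenyl group the same ring gives a 4.0-fold higher number from compound 3 to compound 4 (0.60 log units; beyond the scatter) which leaves compound 3 as the only one of the four set apart from all the others by steps beyond the scatter.

The compounds shown leave open whether that separation of compound 3 follows the methoxy group or its place on the ring, a question a 2-chlorophenyl group would address. On these data alone, how an amine or a carboxylic acid on this phenyl ring would read also remains open. No supporting evidence bears on the cause of these steps.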